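Carbamoyl in place of methyl: compound 3 to compound 4

The source may hold more compounds than are shown below. What is called first, only, known or untested is meant among the compounds shown, and "the series" means these compounds.

Compound 1 `CN(/N=N/c1ccc(C#N)cc1)C(=O)CCc1ccc(O)cc1` gives 5.8 h
Compound 2 `CN(/N=N/c1ccc(C(N)=O)cc1)C(=O)CCc1ccc(O)cc1` gives 48.5 h
Compound 3 `Cc1ccc(/N=N/N(C)C(=O)CCCCc2ccc(O)cc2)cc1` gives 79.7 h

Among the measured compounds shown here, these half-lives come from an ADME assay on a cell-free system (plasma, Homo sapiens) for metabolic stability, read by HPLC (a lower number here means that the compound disappears faster, a higher number that the compound lasts longer), and are the only measurements available for the series. Compound 3 at 79.7 h lies within the scatter of compound 2 and beyond the scatter from compound 1.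

The next structure is compound 4 `CN(/N=N/c1ccc(C(N)=O)cc1)C(=O)CCCCc1ccc(O)cc1` and the difference from compound 3 is carbamoyl in place of methyl on an aromatic carbon with carbamoyl in place of methyl on an aromatic carbon. For the measured compounds named here, no measured step makes this exact change. The closest is an 8.4-fold higher number from compound 1 to compound 2 (0.92 log units; beyond the scatter) but there carbamoyl replaces cyano, so its size does not carry over directly. Compound 2 also bears carbamoyl, and at 48.5 h it lies within the scatter of compound 3 despite having a shorter chain than compound 4. On these data alone, on that basis, no step beyond the scatter is expected in this assay and the direction remains open. The estimated step is a 1.2-fold lower number from compound 3 to compound 4 (0.09 log units; within the scatter) as a working figure. For compound 4 the expected half-life is 65 h within an estimated range of 28 h to 150 h for now.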

Compound 4, half-life: 55.4 h
Compound 4: middle estimate off by 1.2-fold (0.07 log units), on the high side; the range from low to high includes it.
By their numbers in this assay, from the lowest: compound 1; then compounds 2, 4 and 3 (each within the scatter of the next).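

In this assay, carbamoyl in place of methyl on an aromatic carbon, para to a large group, gives a 1.4-fold lower number from compound 3 to compound 4 (0.16 log units; within the scatter). The earlier step at this position, an 8.4-fold higher number from compound 1 to compound 2 (0.92 log units; beyond the scatter), lies beyond the scatter with carbamoyl replacing nitrile, so carbamoyl entering here does not always bring a step of that size. No measurement on hand explains the result.

The two steps sit on different chains, so the part played by the leaving group cannot be separated from that of the chain. Also open, on these data alone, is how an amine or a carboxylic acid at this position would read in this assay, and whether nitrile on the chain of compound 3 would stand apart from methyl and carbamoyl.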